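From 2,4-dichlorophenyl to 2,4-difluorophenyl: working notes

The compounds below may be only part of what the source reports. "The series", "measured", "known", "first", "only" and "open" are said of these compounds alone.

Measured in a functional assay on MCF7 cells (Homo sapiens); a higher number here means a weaker inhibitor of growth, a lower number a stronger inhibitor of growth:
- compound 1 `O=S(=O)(/C=C/c1ccc(Cl)c(Cl)c1)Cc1ccc(Nc2ncnc3ccc(Br)cc23)cc1`: 14000 nM
- compound 2 `O=S(=O)(/C=C/c1ccc(Cl)cc1)Cc1ccc(Nc2ncnc3ccc(Br)cc23)cc1`: 46000 nM
- compound 3 `O=S(=O)(/C=C/c1ccc(Cl)cc1Cl)Cc1ccc(Nc2ncnc3ccc(Br)cc23)cc1`: 4000 nM

Compound 3 has the lowest number of the three at 4000 nM, and the nearest measured step is a 3.5-fold lower number from compound 1 to compound 3 (0.54 log units; beyond the scatter). Compound 4 `O=S(=O)(/C=C/c1ccc(F)cc1F)Cc1ccc(Nc2ncnc3ccc(Br)cc23)cc1` is not yet measured, and its change is 2,4-difluorophenyl in place of 2,4-dichlorophenyl on a double-bonded chain carbon bound to a double-bonded chain carbon. Among the measured compounds shown here, the steps that bear on it both concern chloro: the large 12-fold lower number from compound 2 to compound 3 (1.06 log units; beyond the scatter) and the modest 3.3-fold higher number from compound 1 to compound 2 (0.52 log units; beyond the scatter). For the measured compounds named here, no fluoro compound has been measured, so the guide is indirect. In this assay, a modest rise in the number is expected, with a 2.5-fold higher number from compound 3 to compound 4 (0.40 log units; beyond the scatter) as the estimated step. For compound 4 the estimated value is 10000 nM, with an expected range of 2500 nM to 40000 nM.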

Compound 4, concentration for 50% growth inhibition: 100000 nM
The estimate for compound 4 lay 10-fold (1.00 log units) below the measured number, and the stated range ends below it.
By their numbers in this assay, from the lowest: compound 3; then compound 1; then compound 2; then compound 4.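

In this assay, the two halogens on this ring are not interchangeable: 2,4-difluorophenyl in place of 2,4-dichlorophenyl gives a 25-fold higher number from compound 3 to compound 4 (1.40 log units; beyond the scatter). Compound 4 is the weakest of the series, with a 2.2-fold higher number from compound 2 to compound 4 (0.34 log units; beyond the scatter) and a 7.1-fold higher number from compound 1 to compound 4 (0.85 log units; beyond the scatter), so the positions of the two halogens alone do not secure the low number of compound 3. No measured evidence accounts for this loss.

Still open, from the compounds shown here alone, is how 2,4-dibromophenyl or 2,4-dimethylphenyl would compare with 2,4-dichlorophenyl at this place. Also open, going by these compounds, is whether 4-fluorophenyl would follow the same order.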